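Ethyl to Isopropyl on a Trifluoroethoxy Lactam Core

This account rests on a few compounds, and the source may have more. Where it says the series, first, only, none or still open, it means among the compounds named here.

Measured so far:
compound 1, `CCc1ccc(N2C(=O)C=CC2OCC(F)(F)F)cc1`, 7840 nM
compound 2, `O=C1C=CC(OC(C(F)(F)F)C(F)(F)F)N1c1ccc(Cl)cc1`, 2410 nM

In a functional assay on MDA-MB-231 cells (Homo sapiens) for inhibition (a higher number here means a weaker inhibitor, a lower number a stronger inhibitor), compound 1 gives 7840 nM, the highest of the two numbers; compound 2 gives 2410 nM, and the gap between them lies beyond the scatter. Compound 3, `CC(C)c1ccc(N2C(=O)C=CC2OCC(F)(F)F)cc1`, has not yet been measured. It differs from compound 1 by methyl in place of hydrogen on a saturated chain carbon bound to an aromatic carbon and a saturated chain carbon. A change of this size on the aromatic substituent is expected to move this assay little, with the step of a 1.2-fold lower number from compound 1 to compound 3 (0.08 log units; within the scatter) estimated to stay within the usual scatter, in no firm direction. For compound 3 the estimate is 6500 nM, with a range from 2500 nM to 16000 nM.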

Compound 3, half-maximal inhibitory concentration: 6640 nM
Beside the measured number, compound 3's estimate is 1.0-fold (0.01 log units) below it; the measured number falls inside the stated range.
By their numbers in this assay, from the lowest: compound 2; then compounds 3 and 1 (each within the scatter of the next).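

Ethyl to isopropyl gives a 1.2-fold lower number from compound 1 to compound 3 (0.07 log units; within the scatter) in this assay for this methyl on a saturated chain carbon bound to an aromatic carbon and a saturated chain carbon. Going by these compounds alone, this is the first comparison of compounds differing in one place, and at this position the two compounds cannot be told apart. Nothing available gives a reason for this result.

The compounds shown leave open whether a longer chain, such as n-butyl, or an amine at this place would also stay within the scatter of compound 1. They also leave open how a tert-butyl group would read.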